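The source may hold more compounds than are shown below. What is called first, only, known or untested is meant among the compounds shown, and "the series" means these compounds.

Working notes on the series in an ADME assay on RAW264.7 cells (Mus musculus) for cytotoxicity, read by MTT assay, with a stated time of 24 h; on this read-out higher numbers stand for lower toxicity in this test and lower numbers for higher toxicity in this test. Compound 1 `O=C(Nc1ccc(Cl)cc1F)c1ccccc1` carries no hydroxy on the benzoyl ring; in this assay compound 1 reports only a limit, > 40000 nM, which is the limit of > 40000 nM in this assay, at which 1 of the 3 values shown sits. Compound 2 `O=C(Nc1ccc(I)cc1F)c1ccccc1O` gives 23300 nM in this assay. Compound 3 `O=C(Nc1ccc(I)cc1F)c1ccccc1OCc1ccc(F)cc1F` gives 32600 nM in this assay, and the step of a 1.4-fold higher number from compound 2 to compound 3 (0.15 log units; within the scatter) changes the same oxygen that compound 4 loses. Compound 2 and compound 3 thus sit within the scatter of each other, and the third value in the set is a limit rather than a number.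

Compound 4 `O=C(Nc1ccc(I)cc1F)c1ccccc1` differs from compound 2 by hydrogen in place of hydroxy on an aromatic carbon. Among the measured compounds shown here, no measured pair removes the hydroxy outright; the only measured step at that oxygen, a 1.4-fold higher number from compound 2 to compound 3 (0.15 log units; within the scatter), stays within the scatter, and compound 1, which also has no hydroxy, sits at a limit. The step of a 1.3-fold higher number from compound 2 to compound 4 (0.11 log units; within the scatter) is therefore expected to stay within the scatter. For compound 4 the estimate in this assay is 30000 nM, with a range from 14000 nM to 65000 nM.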

Compound 4, half-maximal cytotoxic concentration: > 40000 nM
Compound 4 ended at the assay's limit (the forecaster's own chance of this, stated with the estimate: 35%); at least 1.3-fold (0.12 log units) between middle value and limit.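

With hydrogen in place of hydroxy on the aromatic carbon, this assay now has a direct pair for the hydroxy itself, which reads as an at least 1.7-fold higher number from compound 2 to compound 4 (0.23 log units; that floor lies within the scatter); no drop in the number appears, so a high number in this test does not depend on the free hydroxy, but the floor gives no evidence of a real rise. Compound 4 reports only a limit, which leaves the true size of this step open on the upper side. Compound 1 and compound 4 both report limits, so the step for iodo in place of chloro cannot be read: the limit of > 40000 nM in this assay, at which 2 of the 4 values shown sit.

As far as these compounds go, whether an amine or a carboxylic acid on the same aromatic carbon would move the number beyond the scatter stays open. Also open, from the compounds shown here alone, is how iodo in place of chloro reads when the hydroxy is present.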